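Swapping the aryl tail on a TLR8 agonist scaffold

The source may report more compounds than this note shows. Statements on the series, on what has been measured and on what is new or still open speak of the compounds shown alone.

Measured compounds:
- Compound 1, `CCCCNc1nc(N)nc2ccc(F)cc12`: 0.1 uM
- Compound 2, `CCCCNc1nc(N)nc2ccc(CCc3ccc(N(C)C)cc3)cc12`: 0.5 uM

Both compounds share a core bearing a butylamino group and an amino group, and they were tested in an ADME assay on HEK293 cells for agonist activity at Toll-like receptor 8 (Homo sapiens), read by a luciferase reporter, with a stated time of 6 h; a higher number here means that more compound is needed for the effect, a lower number that less compound is needed. Compound 1 gives 0.1 uM in this assay. Compound 2 gives 0.5 uM in this assay. Of the two numbers, compound 2 has the higher one, and the gap to compound 1 lies beyond the scatter of repeated measurements, so compound 2 needs more material than compound 1 for the same effect.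

Compound 3, `CCCCNc1nc(N)nc2ccc(CCc3ccccn3)cc12`, has not yet been measured in this assay. It differs from compound 2 by pyridin-2-yl in place of 4-(dimethylamino)phenyl on a saturated chain carbon, two bonds along the chain from an aromatic carbon. Nothing in the measured pair shows how this kind of exchange shifts the read-out, so the expectation rests only on the fact that the core and the two-carbon chain are kept. The step from compound 2 to compound 3 in this assay is estimated to be small, a 1.7-fold lower number from compound 2 to compound 3 (0.22 log units; within the scatter), perhaps toward a lower number but not clearly beyond the scatter. Compound 3 is therefore expected to give about 0.3 uM, within a range from 0.1 uM to 1 uM.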

Compound 3, minimum effective concentration: 0.3 uM
The estimate for compound 3 equals the measured number at the digits printed; low and high end bracket the measured number.
By their numbers in this assay, from the lowest: compound 1; then compounds 3 and 2 (each within the scatter of the next).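

In this assay, putting pyridin-2-yl in place of 4-(dimethylamino)phenyl on a saturated chain carbon, two bonds along the chain from an aromatic carbon, gives a 1.7-fold lower number from compound 2 to compound 3 (0.22 log units; within the scatter) and so leaves the read-out unresolved between the two compounds. Among these compounds, this is the first measured exchange at this place, and it shows that a carbon-only aromatic ring carrying a dimethylamino group and a smaller aromatic ring with one hetero atom cannot be told apart here, even though the two groups differ in heavy-atom count. The other step, 2-(pyridin-2-yl)ethyl in place of fluoro on an aromatic carbon, gives a 3.0-fold higher number from compound 1 to compound 3 (0.48 log units; beyond the scatter) and is a modest loss that does exceed the scatter, so the small fluoro group remains ahead of this larger group on the shared core.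

How far this tolerance extends stays open, since the compounds shown do not reveal what a carboxylic acid or a primary amine in place of pyridin-2-yl, or a longer chain leading to that ring, would do to the read-out. No supporting measurement is available to explain either step.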